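Adding a Branch: From Propyl to Isobutyl

A few compounds are considered here, and "the series" means these few. Any claim that something is new, unique, unknown or untested is made for them only; others in the source may bear on it.

In a functional assay on HeLa cells (Homo sapiens) for antiproliferative activity, read by sulforhodamine B assay (a higher number here means a weaker inhibitor of growth, a lower number a stronger inhibitor of growth), compound 1 (`CC[C@H]1O[C@H](COCc2ccccc2)[C@@H](OCc2ccccc2)[C@H](OCc2ccccc2)[C@H]1O`) gives > 50000 nM as its result, and this is a limit and not a number. For the measured compounds named here, compound 2 (`CCC[C@H]1O[C@H](COCc2ccccc2)[C@@H](OCc2ccccc2)[C@H](OCc2ccccc2)[C@H]1O`) gives 17400 nM in this assay and so holds the only actual number so far, with nothing yet measured on its stronger side. Compound 3 (`CC(C)C[C@H]1O[C@H](COCc2ccccc2)[C@@H](OCc2ccccc2)[C@H](OCc2ccccc2)[C@H]1O`) differs from compound 2 by one change (methyl in place of hydrogen on a saturated chain carbon bound to two saturated chain carbons): methyl in place of hydrogen on a saturated chain carbon bound to two saturated chain carbons, which turns propyl into isobutyl. Going by the values given here, only one measured step bears on this, and it is also a methyl in place of hydrogen on a saturated chain carbon. It is an at least 2.8-fold lower number from compound 1 to compound 2 (0.45 log units; beyond the scatter) and it sets only a lower bound on its own size, since one end of it is a limit. It also sits at a different place on the chain, so it is a loose guide. The expected result is a 1.9-fold lower number from compound 2 to compound 3 (0.29 log units; within the scatter) in this assay, a modest move in the same direction that may stay close to the scatter. Compound 3 is estimated at 9000 nM (expected range 3500 nM to 25000 nM).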

Compound 3, concentration for 50% growth inhibition: 43900 nM
Compound 3: the middle estimate sits 4.9-fold (0.69 log units) below what was measured; measured number outside the range, above it.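

In this assay, methyl in place of hydrogen on a saturated chain carbon bound to two saturated chain carbons, which turns propyl into isobutyl, gives a 2.5-fold higher number from compound 2 to compound 3 (0.40 log units; beyond the scatter). This runs opposite to the earlier methyl step at a different place on the chain, an at least 2.8-fold lower number from compound 1 to compound 2 (0.45 log units; beyond the scatter), so among these compounds an added methyl does not move the number in one direction along the chain, and compound 2, with its propyl chain, has the lowest number of the three. The step of an at least 1.1-fold lower number from compound 1 to compound 3 (0.05 log units; that floor lies within the scatter) rests on a limit for compound 1, and its floor lies within the scatter, so it gives no order for that pair: the limit of > 50000 nM in this assay, at which 1 of the 3 values shown sits.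

The compounds shown leave open whether the higher number of compound 3 belongs to the branch itself or to the added carbon, and a straight butyl chain on the shared core would help separate the two. Going by these compounds, it also remains open how the number would respond to an amine or a carboxylic acid at the end of the propyl chain.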